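Series notes: oxetan-3-yl for isopropyl, compound 3 to compound 4

This account rests on a few compounds, and the source may have more. Where it says the series, first, only, none or still open, it means among the compounds named here.

Measured compounds:
Compound 1 `Cn1ncc2c(NS(=O)(=O)c3cccc(Cl)c3Cl)ncnc21` gives 1260 nM in a functional assay on cells for antagonist activity at C-C chemokine receptor type 4 (Homo sapiens), read by GTPgammaS binding; a higher number here means a weaker inhibitor, a lower number a stronger inhibitor.
Compound 2 `CCn1[nH]c2ncnc(NS(=O)(=O)c3cccc(Cl)c3Cl)c2c1=O` returns only a limit in this assay, > 31600 nM.
Among the measured compounds shown here, compound 2 is the one value that sits at the limit of > 31600 nM in this assay, at which 1 of the 3 values shown sits.
Compound 3 `COc1nn(C(C)C)c2ncnc(NS(=O)(=O)c3cccc(Cl)c3Cl)c12` gives 251 nM in this assay.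

Compound 3 holds the lowest of the two numbers in this assay; the nearest, compound 1, sits higher by a margin beyond the usual scatter. Compound 2 gives no number at all.

Compound 4 `COc1nn(C2COC2)c2ncnc(NS(=O)(=O)c3cccc(Cl)c3Cl)c12` is not yet measured. It differs from compound 3 in one place: oxetan-3-yl in place of isopropyl on an aromatic nitrogen. For the measured compounds named here, no measured pair covers this change, so its size is open. The expectation is a step of modest size toward a weaker value, or none beyond the scatter.

The estimate for compound 4 in this assay is 400 nM, within a range from 120 nM to 1300 nM. This estimate corresponds to an expected step of a 1.6-fold higher number from compound 3 to compound 4 (0.20 log units; within the scatter).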

Compound 4, half-maximal inhibitory concentration: 251 nM
The estimate for compound 4 lay 1.6-fold (0.20 log units) above the measured number; the range from low to high includes it.
By their numbers in this assay, from the lowest: compounds 3 and 4 (each within the scatter of the next); then compound 1. At a limit, above all of these: compound 2.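

In this assay, oxetan-3-yl in place of isopropyl on an aromatic nitrogen gives no change at the digits printed from compound 3 to compound 4 (within the scatter), so this position accepts a four-membered ring carrying a hydrogen-bond acceptor with no readable change in the number. The earlier compounds shown here offered no pair differing in one place, so this is the only measured size of a change at this nitrogen. Nothing at hand accounts for the absence of a readable step.

From the compounds shown here alone, whether other groups on this nitrogen behave the same way stays open, for example an amine-bearing chain, a carboxylic acid or a longer chain. Going by these compounds, the separate contribution of the methoxy group also stays open, since compound 1 differs from compound 3 in more than one place.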